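The compounds below may be only part of what the source reports. "The series", "measured", "known", "first", "only" and "open" are said of these compounds alone.

Working notes on the series, all read in a functional assay on A549 cells (Homo sapiens) for cytotoxicity, read by MTT assay, with a stated time of 72 h; a lower number here means a stronger inhibitor, a higher number a weaker inhibitor. Compound 1 `CNC(=O)c1cc(Oc2ccc(C3=NNC(c4ccc(Cl)cc4Cl)C3)cc2)ccn1` gives 6930 nM. Compound 2 `CNC(=O)c1cc(Oc2ccc(C3=NNC(c4ccc(OC)cc4)C3)cc2)ccn1` gives 13100 nM. Compound 3 `CNC(=O)c1cc(Oc2ccc(C3=NNC(c4ccccc4)C3)cc2)ccn1` gives 8600 nM, a number within the scatter of both others, so the three form a single group with no reliable ranking.

Compound 4 `CNC(=O)c1cc(Oc2ccc(C3=NNC(c4ccc(Br)cc4)C3)cc2)ccn1` is not yet measured. It differs from compound 3 by bromo in place of hydrogen on an aromatic carbon, with bromo in place of hydrogen on an aromatic carbon, para to a large group, so that phenyl becomes 4-bromophenyl.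

Within the data shown here, no measured compound carries bromo, so the evidence is indirect. The closest measured change is hydrogen in place of methoxy on an aromatic carbon, a 1.5-fold lower number from compound 2 to compound 3 (0.18 log units; within the scatter). Phenyl in place of 2,4-dichlorophenyl gives a 1.2-fold higher number from compound 1 to compound 3 (0.09 log units; within the scatter), and 4-methoxyphenyl in place of 2,4-dichlorophenyl gives a 1.9-fold higher number from compound 1 to compound 2 (0.28 log units; within the scatter). All three steps stay within the scatter, so no step beyond the scatter is expected here, and no direction can be favoured.

The estimate amounts to a 1.1-fold lower number from compound 3 to compound 4 (0.03 log units; within the scatter), an expected step within the scatter. For compound 4 the expected value is 8000 nM, with an estimated range of 3800 nM to 16000 nM.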

Compound 4, half-maximal inhibitory concentration: 21000 nM
Beside the measured number, compound 4's estimate is 2.6-fold (0.42 log units) below it; the measured number lies above the stated range.
By their numbers in this assay, from the lowest: compounds 1, 3, 2 and 4 (each within the scatter of the next, the first and the last beyond it).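

Among these compounds, at this place on the aromatic ring, para to a large group, the change from hydrogen to bromo in this assay gives a 2.4-fold higher number from compound 3 to compound 4 (0.39 log units; beyond the scatter), the first step from compound 3 to leave the scatter, so this position is not indifferent to substitution in the way the earlier compounds allowed it to seem. Against the 2,4-dichlorophenyl group, 4-bromophenyl gives a 3.0-fold higher number from compound 1 to compound 4 (0.48 log units; beyond the scatter), which also lies beyond the scatter and shows that these two halogen-bearing aryl groups can be told apart in this series. Bromo and methoxy at the same place remain unresolved, with a 1.6-fold higher number from compound 2 to compound 4 (0.20 log units; within the scatter), so the result separates bromo from hydrogen but not from every other group at this position.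

No available measurement bears on why bromo shifts the number in this direction. Going by these compounds, it remains open whether a single chloro or fluoro, an amine or a carboxylic acid at the same place would follow bromo or stay with hydrogen, and whether any group there could lower the number beyond the scatter.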